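Hydrogen in place of methyl on compound 2

A few compounds are considered here, and "the series" means these few. Any claim that something is new, unique, unknown or untested is made for them only; others in the source may bear on it.

Of the compounds shown here, two have numbers so far. In a physicochemical assay for lipophilicity, read by spectrophotometry, measured as octanol-water partition, at pH 7.4 (a higher number here means a more lipophilic compound, a lower number a more polar compound), compound 1 (`CCOc1cc(CN2CCC(NC(=O)c3ccc(N)nc3)CC2)cc(OCc2ccccc2)c1-c1ccc(F)cc1`) gives 3.94 and compound 2 (`CCOc1cc(CN2CCC(NC(=O)c3ccc(NC)nc3)CC2)cc(OCC)c1-c1ccc(F)cc1`) gives 3.83 on the same scale. These two values lie within the usual scatter of each other, so compound 2 stands level with compound 1 on the present numbers.

Compound 3 (`CCOc1cc(CN2CCC(NC(=O)c3ccc(N)nc3)CC2)cc(OCC)c1-c1ccc(F)cc1`) has not yet been measured in this assay and differs from compound 2 in one place: hydrogen in place of methyl on a nitrogen on an aromatic ring. The methylamino group thus becomes amino, and 6-(methylamino)pyridin-3-yl becomes 6-aminopyridin-3-yl.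

For the measured compounds named here, no measured pair in this small set shows the same change, so its size remains an expectation. A modest fall is expected, about as large as the usual scatter, starting from compound 2 at 3.83 as the reference. The estimated step is a number 0.33 log units lower from compound 2 to compound 3 (beyond the scatter) in this reading. Compound 3 is expected at 3.5 with an estimated range from 3.1 to 3.85 in the same units.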

Compound 3, distribution coefficient: 3.15
Compound 3: middle estimate off by 0.35 log units, on the high side, within the range that was stated.
By their numbers in this assay, from the lowest: compound 3; then compounds 2 and 1 (each within the scatter of the next).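

In this assay, for the compounds shown here, the first measured change on this nitrogen is hydrogen in place of methyl on a nitrogen on an aromatic ring, turning methylamino into amino, and it comes with a number 0.68 log units lower from compound 2 to compound 3 (beyond the scatter). So the number moves by more than the usual scatter of repeated measurements when this one methyl is absent, at least in this setting. The second listed change lies elsewhere in the molecule: methyl in place of phenyl on a saturated chain carbon bound to an oxygen on an aromatic ring comes with a number 0.79 log units lower from compound 1 to compound 3 (beyond the scatter), which shows that the amino compound also differs clearly from its partner at this second place. Nothing shown here gives a measured reason for either step.

As far as these compounds go, each change rests on one pair, so it remains open whether the methylamino to amino step would keep its size on a core carrying the phenyl group. From the compounds shown here alone, it is equally open how an ethyl group or a second methyl group on that nitrogen would compare with the methylamino and amino compounds on this scale.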